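This account rests on a few compounds, and the source may have more. Where it says the series, first, only, none or still open, it means among the compounds named here.

Compound 1 `CCCn1c(=O)c2c(ncn2C)n(C)c1=O` and compound 2 `C=CCn1c(=O)c2c(ncn2C)n(C)c1=O` are built on one shared core. In an assay on cell membranes with adenosine receptor A1 (Rattus norvegicus) as the target (a higher number here means a weaker inhibitor, a lower number a stronger inhibitor), compound 1 gives 38000 nM, and compound 2 gives 47000 nM. The change from one to the other is vinyl in place of ethyl on a saturated chain carbon bound to an aromatic nitrogen, and it made a 1.2-fold higher number from compound 1 to compound 2 (0.09 log units; within the scatter). Compound 3 `CCCn1cnc2c1c(=O)n(C)c(=O)n2CC(C)C` rests on a different core; the difference between the two cores is not broken down here. In this assay compound 3 gives 13000 nM, the lowest of the three numbers, and the gaps to the other two lie beyond the scatter. Compound 4 `C=CCn1cnc2c1c(=O)n(C)c(=O)n2CC(C)C` carries the core of compound 3 with the same change that turned compound 1 into compound 2, namely (vinyl in place of ethyl on a saturated chain carbon bound to an aromatic nitrogen), at a place described in the same words. For compound 4 the expected step is a 1.2-fold higher number from compound 3 to compound 4 (0.06 log units; within the scatter), because the earlier change made only a 1.2-fold higher number from compound 1 to compound 2 (0.09 log units; within the scatter) and gave no sign of a real shift. Compound 4 is therefore estimated at 15000 nM in this assay, with a likely range from 7000 nM to 35000 nM.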

Compound 4, inhibition constant: 13000 nM
For compound 4 the middle estimate is 1.2-fold (0.06 log units) above the measured one; the range from low to high includes it.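

On the core of compound 3, putting vinyl in place of ethyl on a saturated chain carbon bound to an aromatic nitrogen gave no change at the digits printed from compound 3 to compound 4 (within the scatter) in this assay. Set beside the same change on the core shared by compound 1 and compound 2, the step carried over from one core to the other without a difference that can be told from the scatter: the same change on two cores in this assay, a 1.2-fold higher number (0.09 log units; within the scatter) from compound 1 to compound 2 and no change at the digits printed (within the scatter) from compound 3 to compound 4, 1.2-fold (0.09 log units) apart, within the scatter of two such steps. This supports treating propyl and allyl as interchangeable in this assay on these two cores only; it does not show that the same would hold on a further core, and steps this small cannot reveal a slight real shift or explain why the number stays put.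

The compounds shown leave open whether a longer chain, such as butyl, or a benzyl group at this place would move the number beyond the scatter. They also leave open what an amine or a carboxylic acid on that chain would do.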